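Antiproliferative series on A549 cells: acrylamide versus branched enamide

This account rests on a few compounds, and the source may have more. Where it says the series, first, only, none or still open, it means among the compounds named here.

Measured compounds:
compound 1 `COc1cc(N(C)CCN(C)C)c(NC(=O)/C=C\C(C)C)cc1Nc1nccc(-c2cn(C)c3ccc(F)cc23)n1`, 6140 nM
compound 2 `C=CC(=O)Nc1cc(Nc2ncc(C#N)c(-c3cn(C)c4ccc(F)cc34)n2)c(OC)cc1N(C)CCN(C)C`, 9700 nM

In a functional assay on A549 cells (Homo sapiens) for antiproliferative activity, read by MTT assay, with a stated time of 72 h (a higher number here means a weaker inhibitor, a lower number a stronger inhibitor), compound 2 gives 9700 nM, the higher of the two numbers shown. Its nearest neighbour is compound 1, which in this assay gives 6140 nM; the gap between the two is within the scatter, so no order can be read from it. Among the compounds with values here, no single-change pair exists among the measured compounds, and the two differ at more than one place, so only their values can be compared.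

Compound 3 `COc1cc(N(C)CCN(C)C)c(NC(=O)/C=C\C(C)C)cc1Nc1ncc(C#N)c(-c2cn(C)c3ccc(F)cc23)n1` carries the change (3-methylbut-1-en-1-yl in place of vinyl on a carbonyl carbon), that is, 3-methylbut-1-en-1-yl in place of vinyl on a carbonyl carbon, with the rest of compound 2 kept. The same amide already sits in compound 1. The step of a 1.3-fold lower number from compound 2 to compound 3 (0.11 log units; within the scatter) is expected to stay within the scatter, with no clear direction. Compound 3 is therefore estimated at 7500 nM, with a range from 2500 nM to 25000 nM.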

Compound 3, half-maximal inhibitory concentration: 185 nM
For compound 3 the middle estimate is 41-fold (1.61 log units) above the measured one; the measured number lies below the stated range.
By their numbers in this assay, from the lowest: compound 3; then compounds 1 and 2 (each within the scatter of the next).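

In this assay, with the nitrile present, 3-methylbut-1-en-1-yl in place of vinyl on a carbonyl carbon gives a 52-fold lower number from compound 2 to compound 3 (1.72 log units; beyond the scatter) and so marks this amide position as highly sensitive to the group it carries. With that amide kept, cyano in place of hydrogen on an aromatic carbon gives a 33-fold lower number from compound 1 to compound 3 (1.52 log units; beyond the scatter) and shows that the amide change alone does not account for the result. Within the data shown here, compounds 1 and 2, whose values lie within the scatter of each other, gave no sign of either step.

No measurement shown here bears on the cause of these steps.

On these data alone, whether the two changes act independently or depend on each other stays open, since that reading needs the vinyl amide with hydrogen in place of cyano. Also open, as far as these compounds go, is how a longer chain or a dimethylamino group on the carbonyl-bound alkenyl group would compare with 3-methylbut-1-en-1-yl.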